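Tetrafluoroethoxy in place of trifluoromethylsulfanyl on the shared core

The compounds below may be only part of what the source reports. "The series", "measured", "known", "first", "only" and "open" are said of these compounds alone.

Measured compounds:
compound 1 `Oc1nc2nonc2nc1Nc1ccc(SC(F)(F)F)cc1`: 1400 nM
compound 2 `Oc1nc2nonc2nc1NC(c1ccccc1)c1ccccc1`: 38300 nM

In an assay on mitochondria from L6 cells (Rattus norvegicus) for activation, with a stated time of 90 min (on this read-out higher numbers stand for an effect only at larger amounts of compound and lower numbers for an effect already at smaller amounts), compound 1 gives 1400 nM, the lowest of the two numbers, while compound 2 gives 38300 nM, a difference beyond the usual scatter. Compound 3 `Oc1nc2nonc2nc1Nc1ccc(OC(F)(F)C(F)F)cc1` is not yet measured. It differs from compound 1 by 1,1,2,2-tetrafluoroethoxy in place of (trifluoromethyl)sulfanyl on an aromatic carbon. For the measured compounds named here, with no measured step of this kind available, the change is expected to give a step from compound 1 to compound 3 of about a 1.4-fold higher number from compound 1 to compound 3 (0.15 log units; within the scatter), that is, little beyond the scatter. Compound 3 is therefore estimated at 2000 nM, within a range from 600 nM to 7000 nM.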

Compound 3, half-maximal effective concentration: 7000 nM
Compound 3: middle estimate off by 3.5-fold (0.54 log units), on the low side; the measured number falls inside the stated range.
By their numbers in this assay, from the lowest: compound 1; then compound 3; then compound 2.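

In this assay, 1,1,2,2-tetrafluoroethoxy in place of (trifluoromethyl)sulfanyl on the aromatic carbon gives a 5.0-fold higher number from compound 1 to compound 3 (0.70 log units; beyond the scatter). For the compounds shown here, this is the first reading of a single change at this position, and it shows that the number responds to the group held there, even though both groups are uncharged and without a ring. Nothing available accounts for the direction or size of this step. Open, on these data alone, is how an amine, a carboxylic acid or a longer perfluoroalkyl chain would fare on this carbon. Also open, as far as these compounds go, is whether the same replacement would give a similar step on another aromatic substituent pattern.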